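The source may report more compounds than this note shows. Statements on the series, on what has been measured and on what is new or still open speak of the compounds shown alone.

Compound 1 `CNC(=O)OCc1c2c(n(C)c1COC(=O)NC)C(=O)C(C)=C(OC)C2=O`: < 0.03 ug/mL
Compound 2 `CNC(=O)OCc1c2c(n(C)c1COC(C)=O)C(O)=C(C)C(=N)C2=O`: > 31 ug/mL
Compound 3 `CNC(=O)OCc1c2c(n(C)c1COC(=O)NC)C(O)=C(C)C(=N)C2=O`: not yet measured

Both measured compounds were tested in a functional assay on HCT-116 cells (Homo sapiens) for antiproliferative activity; on this read-out lower numbers stand for stronger inhibition and higher numbers for weaker inhibition. Compound 1 gives < 0.03 ug/mL, which is a limit of the assay rather than a number. Compound 2 gives > 31 ug/mL, again a limit and not a number. Of the two values shown, one sits at the limit of < 0.03 ug/mL in this assay, at which 1 of the 2 values shown sits, and the other at the limit of > 31 ug/mL in this assay, at which 1 of the 2 values shown sits, so compound 2 stands at the weak end of what has been seen.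

Compound 3 differs from compound 2 in one place: methylamino in place of methyl on a carbonyl carbon. For the measured compounds named here, no measured step covers this change on its own, so its size cannot be read from the data. Compound 3 carries the two ((methylcarbamoyl)oxy)methyl groups seen in compound 1 but the core of compound 2, so the step of an at least 31-fold lower number from compound 2 to compound 3 (1.49 log units; beyond the scatter) is expected to run toward stronger inhibition, of uncertain size. Compound 3 is expected near 1 ug/mL, within 0.05 ug/mL to 31 ug/mL.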

Compound 3, half-maximal inhibitory concentration: 3.7 ug/mL
Compound 3: middle estimate off by 3.7-fold (0.57 log units), on the low side; the measured number falls inside the stated range.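

In this assay compound 2 gives > 31 ug/mL, which is a limit of the assay and not a number. Replacing acetoxymethyl with ((methylcarbamoyl)oxy)methyl, which puts methylamino in place of methyl on a carbonyl carbon, gives an at least 8.3-fold lower number from compound 2 to compound 3 (0.92 log units; beyond the scatter), so activity on this shared core responds to the change and moves toward stronger inhibition. This size is only a minimum and the real gap may be larger, as compound 2 stands at the edge of what the assay reports: the limit of > 31 ug/mL in this assay, at which 1 of the 3 values shown sits.

As far as these compounds go, whether methylamino is the best group here stays open, as a single pair cannot show how ethylamino, dimethylamino or a longer alkyl chain on that carbonyl carbon would compare. This pair also cannot show why the change matters, or whether the same swap would have a similar effect on the core of compound 1.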